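The source may report more compounds than this note shows. Statements on the series, on what has been measured and on what is new or still open speak of the compounds shown alone.

In an ADME assay on MDCK cells (Canis lupus familiaris) for cytotoxicity, with a stated time of 48 h (on this read-out higher numbers stand for lower toxicity in this test and lower numbers for higher toxicity in this test), compound 1 (`C=C(C(=O)OC)[C@@H]1CC[C@H](C)[C@H]2C(=C(C)C(=O)[C@H]2NC(C)=O)C1`) gives 753 uM and compound 2 (`C=C(C(=O)OC)[C@@H]1CC[C@H](C)[C@H]2C(=C(C)C(=O)[C@H]2NC(=O)CNC(=O)c2ccccc2)C1`) gives 488 uM so the two numbers lie within the scatter of each other. Among the measured compounds shown here, the only measured step replaces hydrogen with benzamido on a saturated chain carbon bound to a carbonyl carbon. The change to compound 3 (`C=C(C(=O)OC)[C@@H]1CC[C@H](C)[C@H]2C(=C(C)C(=O)[C@H]2NC(=O)c2ccc(B(O)O)cc2)C1`) is a group of 9 heavy atoms (6 carbon, 1 boron, 2 oxygen; one six-membered aromatic ring of carbon only) in place of a group of 10 heavy atoms (8 carbon, 1 nitrogen, 1 oxygen; one six-membered aromatic ring of carbon only), on a carbonyl carbon and it sits on a carbonyl carbon whose other neighbours are: amide-type nitrogen. The group that leaves is benzamidomethyl, and the group that enters has no common name. For the measured compounds named here, no measured compound carries the entering group, so the one measured step is only an indirect guide. Because a 1.5-fold lower number from compound 1 to compound 2 (0.19 log units; within the scatter) stays within the scatter, no step beyond the scatter is expected in this assay and no firm direction can be given. The expected step is a 1.1-fold lower number from compound 2 to compound 3 (0.04 log units; within the scatter) and it is not expected to exceed the scatter. For compound 3 the estimated value is 450 uM with an expected range from 150 uM to 900 uM in this read-out.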

Compound 3, half-maximal toxic concentration: 188 uM
For compound 3 the middle estimate is 2.4-fold (0.38 log units) above the measured one; the range from low to high includes it.
By their numbers in this assay, from the lowest: compound 3; then compounds 2 and 1 (each within the scatter of the next).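

In this assay, the group on a carbonyl carbon whose other neighbours are: amide-type nitrogen can shift the number beyond the scatter, which the benzamido step from the earlier pair did not show. The boron-bearing group in place of benzamidomethyl gives a 2.6-fold lower number from compound 2 to compound 3 (0.41 log units; beyond the scatter), and the same group in place of one carbon atom gives a 4.0-fold lower number from compound 1 to compound 3 (0.60 log units; beyond the scatter), so both steps into compound 3 point the same way and both are modest, with compound 3 holding the lowest number of the three. No measurement in hand bears on why this group lowers the number at this position.

The compounds shown leave open whether the step belongs to the boron and its oxygens or to an aromatic ring of carbon sitting on the carbonyl carbon, since compound 3 differs from compound 2 in both at once. A plain phenyl group on that carbonyl carbon, or a carboxylic acid on the aromatic ring in place of the boron-bearing part, would separate the two readings.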